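Methyl on the piperidine ring of compound 3

A few compounds are considered here, and "the series" means these few. Any claim that something is new, unique, unknown or untested is made for them only; others in the source may bear on it.

Measured compounds:
Compound 1, `CN(C)CCn1c2ccc3ccccc3c2c2nc3ccccc3nc21`: in an assay on nucleic acid for binding affinity to Calf thymus DNA (Bos taurus) (a higher number here means a weaker inhibitor, a lower number a stronger inhibitor), compound 1 gives 14500 nM.
Compound 2, `CCN(CC)CCn1c2ccc3ccccc3c2c2nc3ccccc3nc21`: in this assay compound 2 gives 20400 nM.
Compound 3, `c1ccc2c(c1)ccc1c2c2nc3ccccc3nc2n1CCN1CCCCC1`: in this assay compound 3 gives 30900 nM.

Compound 3 has the highest number of the three, which here means the weakest binding. Its step from compound 1, a 2.1-fold higher number from compound 1 to compound 3 (0.33 log units; beyond the scatter), lies beyond the scatter; its step from compound 2, a 1.5-fold higher number from compound 2 to compound 3 (0.18 log units; within the scatter), does not.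

Compound 4, `CC1CCN(CCn2c3ccc4ccccc4c3c3nc4ccccc4nc32)CC1`, is compound 3 with one change: methyl in place of hydrogen on a saturated ring carbon. The measured steps all enlarge the amine on the side chain: a 1.4-fold higher number from compound 1 to compound 2 (0.15 log units; within the scatter) and a 2.1-fold higher number from compound 1 to compound 3 (0.33 log units; beyond the scatter). Each enlargement gave a higher number or no clear change, so a further methyl on the ring is expected to add little, at most a small rise.

Compound 4 is therefore estimated in this assay at 36000 nM, within 17000 nM to 75000 nM, an expected step of a 1.2-fold higher number from compound 3 to compound 4 (0.07 log units; within the scatter).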

Compound 4, half-maximal inhibitory concentration: 33100 nM
Compound 4: middle estimate off by 1.1-fold (0.04 log units), on the high side, and the stated range covers the measured number.
By their numbers in this assay, from the lowest: compounds 1, 2, 3 and 4 (each within the scatter of the next, the first and the last beyond it).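

In this assay, placing methyl on the piperidine ring, three ring bonds from the ring nitrogen, gives a 1.1-fold higher number from compound 3 to compound 4 (0.03 log units; within the scatter), so this small addition on the ring leaves no clear mark on the number. Measured against the amines without a ring, compound 4 behaves as compound 3 did: a 1.6-fold higher number from compound 2 to compound 4 (0.21 log units; within the scatter) stays inside the scatter, while a 2.3-fold higher number from compound 1 to compound 4 (0.36 log units; beyond the scatter) lies beyond it, though only modestly. No supporting measurement is available to explain why the methyl changes so little.

From the compounds shown here alone, it remains open whether a larger group on the same ring carbon, such as a phenyl ring or a hydroxyl, would leave the number equally unchanged. A piperazine in place of the piperidine, or a longer chain between the amine and the core, also remains untested among these compounds.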